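Solubility across the indole-carboxamide piperazinone series

A few compounds are considered here, and "the series" means these few. Any claim that something is new, unique, unknown or untested is made for them only; others in the source may bear on it.

Compound 2 `COc1ccc2[nH]c(C(=O)N3CC(=O)N(Cc4ccccc4)[C@@H](N4CCc5ccccc54)C3)cc2c1` sits lowest of the two numbers in a physicochemical assay for solubility, read by spectrophotometry, in phosphate buffer, with a stated time of 2 h, at pH 7.4 (on this read-out higher numbers stand for higher solubility and lower numbers for lower solubility), giving 7000 nM. Compound 1 `O=C(c1cc2cc(C3CC3)ccc2[nH]1)N1CC(=O)N(Cc2ccccc2)[C@@H](CN2CCC(F)CC2)C1` gives 12400 nM in this assay, within the scatter of compound 2. For compound 3 `COc1ccc2[nH]c(C(=O)N3CC(=O)N(Cc4ccccc4)[C@@H](CN4CCN(Cc5ccccn5)CC4)C3)cc2c1` the read-out in this assay is reported only as a limit, > 100000 nM; one of the three values sits there (the limit of > 100000 nM in this assay, at which 1 of the 3 values shown sits). Compound 4 `COc1ccc2[nH]c(C(=O)N3CC(=O)N(Cc4ccccc4)[C@@H](CN4CCc5ccccc5C4)C3)cc2c1` is not yet measured; it differs from compound 2 in one place: (1,2,3,4-tetrahydroisoquinolin-2-yl)methyl in place of 2,3-dihydro-1H-indol-1-yl on a saturated ring carbon. Within the data shown here, no step between measured compounds exists for this exchange, so the expectation rests on the two numbers and the limit above. Compound 4 is expected to give 25000 nM in this assay, in the range 8000 nM to 80000 nM, a step of a 3.6-fold higher number from compound 2 to compound 4 (0.55 log units; beyond the scatter) estimated to lie beyond the scatter, towards higher solubility.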

Compound 4, solubility: 9000 nM
Compound 4: middle estimate off by 2.8-fold (0.44 log units), on the high side; the range from low to high includes it.
By their numbers in this assay, from the lowest: compounds 2, 4 and 1 (each within the scatter of the next). At a limit, above all of these: compound 3.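

At this saturated ring carbon, the ring-size and heavy-atom exchange gives a 1.3-fold higher number from compound 2 to compound 4 (0.11 log units; within the scatter) in this assay, so (1,2,3,4-tetrahydroisoquinolin-2-yl)methyl and 2,3-dihydro-1H-indol-1-yl are not separated on this read-out. For compound 3 the value > 100000 nM is a limit of the assay, not a number. Nothing measured here bears on a cause for this step.

Open, going by these compounds, is whether a carboxylic acid or a primary amine at this position would give a step beyond the scatter from compound 2.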